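Replacing the dioxopiperidinyl carbonyl with an isobutyl amide

The source may report more compounds than this note shows. Statements on the series, on what has been measured and on what is new or still open speak of the compounds shown alone.

Measured compounds:
compound 1 `Nc1sc(-c2ccc(Cl)cc2)c(-c2ccc(Cl)cc2)c1C(=O)NCc1ccccc1` 31800 nM
compound 2 `COc1ccc(CNC(=O)c2c(N)sc(-c3ccc(Cl)cc3)c2-c2ccc(Cl)cc2)cc1` 29500 nM
compound 3 `Nc1sc(-c2ccc(Cl)cc2)c(-c2ccc(Cl)cc2)c1C(=O)N1CCC(=O)CC1=O` 9230 nM

In a functional assay on PC-3 cells (Homo sapiens) for inhibition, read by sulforhodamine B assay, with a stated time of 72 h (on this read-out lower numbers stand for stronger inhibition and higher numbers for weaker inhibition), compound 3 gives the lowest of the three numbers; compound 2 sits nearest to it and compound 1 furthest. The unmeasured compound 4 `CC(C)CNC(=O)c1c(N)sc(-c2ccc(Cl)cc2)c1-c1ccc(Cl)cc1` differs from compound 3 by isobutylamino in place of 2,4-dioxopiperidin-1-yl on a carbonyl carbon. For the measured compounds named here, the steps that bear on this change run the other way: a 3.4-fold lower number from compound 1 to compound 3 (0.54 log units; beyond the scatter) and a 3.2-fold lower number from compound 2 to compound 3 (0.50 log units; beyond the scatter), both modest and beyond the scatter. Compound 4 carries a secondary amide of the same kind as compound 1 and compound 2, so a modest return to higher numbers is expected, as a 3.0-fold higher number from compound 3 to compound 4 (0.48 log units; beyond the scatter). Compound 4 is therefore estimated at 28000 nM, between 12000 nM and 65000 nM.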

Compound 4, half-maximal inhibitory concentration: 13200 nM
For compound 4 the middle estimate is 2.1-fold (0.33 log units) above the measured one; measured number inside the range.
By their numbers in this assay, from the lowest: compounds 3 and 4 (each within the scatter of the next); then compounds 2 and 1 (each within the scatter of the next).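

In this assay the isobutylamino group leaves the number within the scatter of the 2,4-dioxopiperidin-1-yl group (a 1.4-fold higher number from compound 3 to compound 4 (0.16 log units; within the scatter)), so this carbonyl carbon does not need a ring to reach that level. Compound 4 also keeps the amide hydrogen of the benzyl amides and still separates from them (a 2.2-fold lower number from compound 2 to compound 4 (0.35 log units; beyond the scatter); a 2.4-fold lower number from compound 1 to compound 4 (0.38 log units; beyond the scatter)), so the secondary amide alone does not go with their higher numbers. Nothing measured here explains these steps. The compounds shown leave open whether an ethyl group, a longer chain, or a chain ending in an amine or a carboxylic acid would hold this level.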